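Hydroxy for methoxy in the cyanomethyl pyrazole set

The source may report more compounds than this note shows. Statements on the series, on what has been measured and on what is new or still open speak of the compounds shown alone.

Measured so far:
compound 1, `COc1cc(C)cc(-c2c(-c3ccnc(-c4ccc(C(C)=O)cc4)c3)cnn2CC#N)c1`: in a functional assay on SNB-19 cells (Homo sapiens) for inhibition, read by sulforhodamine B assay, with a stated time of 48 h (a higher number here means that more compound is tolerated, a lower number that less compound is tolerated), compound 1 gives > 100000 nM, a limit.
compound 2, `Cc1cc(O)cc(-c2nn(CC#N)cc2-c2ccnc(-c3ccc(Oc4ccccc4)cc3)c2)c1`: in this assay compound 2 gives 51100 nM.
compound 3, `COc1cc(C)cc(-c2nn(CC#N)cc2-c2ccnc(-c3ccc(N(C)C)cc3)c2)c1`: in this assay compound 3 gives > 100000 nM, a limit.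

Compound 3 thus sits at the limit of > 100000 nM in this assay, at which 2 of the 3 values shown sit, so its value is a limit and not a number. Among the measured compounds shown here, compound 2 is the only member of the set that returns a number in this assay.

Compound 4, `Cc1cc(O)cc(-c2nn(CC#N)cc2-c2ccnc(-c3ccc(N(C)C)cc3)c2)c1`, differs from compound 3 by hydrogen in place of methyl on an oxygen on an aromatic ring — hydrogen in place of methyl on an oxygen on an aromatic ring. For the measured compounds named here, no step between measured compounds is available for this change, so the size of the step can only be guessed. The expected step is a number no higher from compound 3 to compound 4 (the limit leaves the size open), that is no change beyond the scatter. Compound 4 is estimated at 100000 nM, with a range of 40000 nM to 300000 nM.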

Compound 4, concentration lethal to 50% of the cells: > 100000 nM
Compound 4: a limit, no number (the forecaster's own chance of this, stated with the estimate: 60%); the middle value lies on the limit itself.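

Hydroxy in place of methoxy on the 3-methoxy-5-methylphenyl group does not by itself bring a number in this assay, and the step between the two limits cannot be read. Dimethylamino in place of phenoxy on an aromatic carbon gives an at least 1.9-fold higher number from compound 2 to compound 4 (0.29 log units; that floor lies within the scatter), so this pair does not show a change beyond the scatter. Most of the set now rests on one limit: the limit of > 100000 nM in this assay, at which 3 of the 4 values shown sit.

From the compounds shown here alone, the step from methoxy to hydroxy stays open for a compound carrying phenoxy. Also open, going by these compounds, is the outcome of an amino group or fluorine in place of hydroxy.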